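A few compounds are considered here, and "the series" means these few. Any claim that something is new, unique, unknown or untested is made for them only; others in the source may bear on it.

Of the compounds shown here, three with a shared core have been measured in a functional assay on the whole organism (strain CF-1) for positive allosteric modulation, with Mus musculus as the target; on this read-out lower numbers stand for an effect already at smaller amounts and higher numbers for an effect only at larger amounts of compound. Compound 1, `NCC(=O)Nc1ccc(Cl)cc1C(=O)c1ccccc1`, gives 2.5 mg/kg in this assay. Compound 2, `Cc1nnc(CN(C)C)n1-c1ccc(Cl)cc1C(=O)c1ccccc1`, gives 1.1 mg/kg, the lowest number of the three. Compound 3, `CN(C)Cc1nn(CO)c(=O)n1-c1ccc(Cl)cc1C(=O)c1ccccc1Cl`, gives 2 mg/kg, which lies within the scatter of the number for compound 2; only the gap between compound 2 and compound 1 lies beyond the scatter, so compound 2 cannot be called the most potent of the set on these numbers.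

The new compound 4, `CCNCc1nnc(C)n1-c1ccc(Cl)cc1C(=O)c1ccccc1`, differs from compound 2 in one place: ethylamino in place of dimethylamino on a saturated chain carbon bound to an aromatic carbon. The two compounds hold the same atoms, joined differently. Within the data shown here, no pair among the measured compounds shows the effect of such a change, so there is no step in this assay to lean on. In its absence the expectation is that compound 4 will give a number close to that of compound 2, with the step of a 1.3-fold higher number from compound 2 to compound 4 (0.10 log units; within the scatter) expected to stay within the scatter. Compound 4 is therefore estimated at 1.4 mg/kg, with a range from 0.5 mg/kg to 4 mg/kg.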

Compound 4, dose for half-maximal effect: 0.6 mg/kg
Estimate against measurement, compound 4: 2.3-fold (0.37 log units) above; the measured number falls inside the stated range.
By their numbers in this assay, from the lowest: compounds 4, 2, 3 and 1 (each within the scatter of the next, the first and the last beyond it).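

In this assay, the first step read at this position is a 1.8-fold lower number from compound 2 to compound 4 (0.26 log units; within the scatter), so ethylamino in place of dimethylamino on a saturated chain carbon bound to an aromatic carbon leaves the number within the scatter. This exchange keeps the heavy-atom count and adds one hydrogen-bond donor, and that added donor comes with no change that can be told from the scatter in this single pair. No measured information bears on why the step has this size.

On these data alone, it remains open whether methylamino, a free amino group or a longer chain such as propylamino on the same carbon would also stay within the scatter. As far as these compounds go, it is equally open whether the same exchange would behave alike on the core of compound 3, which also carries dimethylamino.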